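Second pyridin-2-yl on the diaryl ester of the series

A few compounds are considered here, and "the series" means these few. Any claim that something is new, unique, unknown or untested is made for them only; others in the source may bear on it.

Compound 1 `CC(C)c1cccc(C(C)C)c1NC(=O)CC(=O)OC(c1ccccc1)c1ccccc1` gives 38 nM in an assay on microsomes from intestine for inhibition of acyl-CoA:cholesterol acyltransferase (Oryctolagus cuniculus); a lower number here means a stronger inhibitor, a higher number a weaker inhibitor. Compound 2 `CCCCCCCCCCC(C)OC(=O)CC(=O)Nc1c(C(C)C)cccc1C(C)C` gives 6 nM in this assay. Compound 3 `CC(C)c1cccc(C(C)C)c1NC(=O)CC(=O)OC(c1ccccc1)c1ccccn1` shows only a limit in this assay, namely > 5000 nM; see (the limit of > 5000 nM in this assay, at which 1 of the 3 values shown sits). Going by the values given here, the step of an at least 130-fold higher number from compound 1 to compound 3 (2.11 log units; beyond the scatter) is the only measured step on this position. Compound 4 `CC(C)c1cccc(C(C)C)c1NC(=O)CC(=O)OC(c1ccccn1)c1ccccn1` repeats that change on the remaining phenyl: pyridin-2-yl in place of phenyl on a saturated chain carbon bound to an aromatic carbon and an oxygen next to a carbonyl group. Among the compounds with values here, since compound 3 already sits at the limit, no direction can be read from its number, and the single step from compound 1 to compound 3 points toward weaker inhibition with each pyridin-2-yl. Compound 4 is therefore expected to remain at or beyond the limit, with an estimated 10000 nM (range 3000 nM to 50000 nM), the expected step being a step that the limit leaves unreadable from compound 3 to compound 4.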

Compound 4, half-maximal inhibitory concentration: > 5000 nM
Compound 4: a limit, no number; the forecaster's own chance of this, stated with the estimate: 85%; the middle value lies beyond the limit too.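

Compound 3 and compound 4 both stand as limits, not numbers, so no step between them can be read in this assay: the limit of > 5000 nM in this assay, at which 2 of the 4 values shown sit.

Left open is whether pyridin-2-yl in place of the remaining phenyl changes inhibition at all.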